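Sulfonamide nitrogen substituent: pyridinyl to pyrimidinyl

The source may report more compounds than this note shows. Statements on the series, on what has been measured and on what is new or still open speak of the compounds shown alone.

Measured in a functional assay on HeLa cells (Homo sapiens) for antiproliferative activity, read by sulforhodamine B assay, with a stated time of 48 h; a higher number here means a weaker inhibitor, a lower number a stronger inhibitor:
compound 1 `N=C(N)NS(=O)(=O)c1ccc(N/C(S)=N\c2ccnc3cc(C(F)(F)F)ccc23)cc1` gives 23900 nM
compound 2 `O=S(=O)(Nc1ccccn1)c1ccc(N/C(S)=N\c2ccnc3cc(C(F)(F)F)ccc23)cc1` gives 68800 nM

Within the data shown here, compound 2 stands with the highest of the two numbers in this assay; the only measured step is a 2.9-fold higher number from compound 1 to compound 2 (0.46 log units; beyond the scatter). Compound 3 `O=S(=O)(Nc1ncccn1)c1ccc(N/C(S)=N\c2ccnc3cc(C(F)(F)F)ccc23)cc1` differs from compound 2 by pyrimidin-2-yl in place of pyridin-2-yl on a sulfonamide nitrogen. The step from compound 1 to compound 2 swapped a non-ring group for a six-membered aromatic ring and bears only loosely on a swap of one such ring for another. Among the measured compounds shown here, no measured step covers this exchange, so a step of a 1.0-fold higher number from compound 2 to compound 3 (0.01 log units; within the scatter) within the scatter is expected. Compound 3 is estimated at 70000 nM, range 30000 nM to 160000 nM.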

Compound 3, half-maximal inhibitory concentration: "not active" (no number reported)
Nothing numeric was reported for compound 3; no gap can be computed for the estimate.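

Among these compounds, compound 3 is reported in this assay as "not active" with no number, so no step from compound 2 to compound 3 can be read. As far as these compounds go, the size of any shift from pyridin-2-yl to pyrimidin-2-yl stays open. No evidence shown bears on this result.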